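The source may hold more compounds than are shown below. What is called first, only, known or untested is meant among the compounds shown, and "the series" means these compounds.

Series notes. Compound 1 `COc1ccc2nc(-c3ccccc3)cc(-c3ccccc3)c2c1` carries a methoxy on a six-membered aromatic ring of carbon only within the shared core, with two phenyl groups on the other ring. For the measured compounds named here, in an ADME assay on CCD 19Lu cells (Homo sapiens) for antiproliferative activity, read by MTT assay, with a stated time of 24 h (a lower number here means a stronger inhibitor, a higher number a weaker inhibitor), compound 1 gives 925000 nM, a very weak result and the only number in hand. Going by the values given here, compound 2 `O=[N+]([O-])c1cccc(-c2cc(-c3ccccc3)c3cc(Br)ccc3n2)c1` in this assay gives "not determined" (no result reported), and compound 3 `N#Cc1ccc(-c2cc(-c3ccccc3)c3cc(Br)ccc3n2)cc1` in this assay gives "not determined" (no result reported), so neither adds a number to set beside compound 1, which therefore stands alone; no step between two measured compounds exists.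

Compound 4 `Brc1ccc2nc(-c3ccccc3)cc(-c3ccccc3)c2c1` is the next step. The change from compound 1: bromo in place of methoxy on an aromatic carbon. Nothing else on the core or the phenyl groups moves. Among the compounds with values here, with only the weak result of compound 1 925000 nM as an anchor and no measured step to gauge a swap of bromo for methoxy, the expected step of a 1.2-fold lower number from compound 1 to compound 4 (0.06 log units; within the scatter) in this assay is one that stays within the scatter, in no clear direction. Compound 4 is thus estimated at 800000 nM in this assay, with a range from 300000 nM to 2000000 nM.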

Compound 4, half-maximal inhibitory concentration: 669000 nM
The estimate for compound 4 lay 1.2-fold (0.08 log units) above the measured number, and the stated range covers the measured number.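

In this assay, for the compounds shown here, the swap of methoxy for bromo on this aromatic carbon gives a 1.4-fold lower number from compound 1 to compound 4 (0.14 log units; within the scatter), the first step that can be read at this position. Two substituents that differ in heavy atoms and in hydrogen-bond acceptors therefore cannot be told apart here, and the replacement opens no clear direction for the series. No supporting measurement bears on this result.

From the compounds shown here alone, whether an amine, a carboxylic acid or a longer alkoxy chain on the same carbon would give a step beyond the scatter stays open. Going by these compounds, the steps from compound 4 to compound 2 and compound 3 cannot be read, so what a nitro or nitrile group on the phenyl substituent does also stays open.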